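Shortening the Isothiocyanate Tether to the Aromatic Ring

The source may report more compounds than this note shows. Statements on the series, on what has been measured and on what is new or still open speak of the compounds shown alone.

Compound 1, `CN(C)C(=O)c1cc2cnc(Nc3ccc(S(=O)(=O)NCCCCCN=C=S)cc3)nc2n1C1CCCC1`: 56.6%
Compound 2, `CN(C)C(=O)c1cc2cnc(Nc3ccc(C(=O)NCCCN=C=S)cc3)nc2n1C1CCCC1`: 32.9%
Compound 3, `CN(C)C(=O)c1cc2cnc(Nc3ccc(NC(=O)CCCCCN=C=S)cc3)nc2n1C1CCCC1`: 56.1%

In a functional assay on A549 cells (Homo sapiens) for inhibition, read by CCK-8 assay, with a stated time of 72 h, tested at 1 uM (a higher number here means a stronger effect of the compound at the concentration tested, a lower number a weaker effect), compound 3 stands second highest of the three numbers. Compound 1 is its nearest neighbour, and the step of a number 0.5 percentage points lower from compound 1 to compound 3 (within the scatter) lies within the scatter, although the two compounds carry different tethers. Compound 2 is furthest away, with the step of a number 23.2 percentage points higher from compound 2 to compound 3 (beyond the scatter) beyond the scatter, and the step of a number 23.7 percentage points lower from compound 1 to compound 2 (beyond the scatter) points the same way.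

Compound 4, `CN(C)C(=O)c1cc2cnc(Nc3ccc(N=C=S)cc3)nc2n1C1CCCC1`, differs from compound 3 as follows: a group of 3 heavy atoms (1 carbon, 1 nitrogen, 1 sulfur; no ring) in place of a group of 11 heavy atoms (7 carbon, 2 nitrogen, 1 oxygen, 1 sulfur; no ring), on an aromatic carbon. The two steps beyond the scatter both involve exchanging one tether for another, and each is modest in size; the step to compound 4 removes the tether altogether, a larger change than any measured here. Because the shorter tether gave the lower number in a number 23.2 percentage points higher from compound 2 to compound 3 (beyond the scatter), a decrease is expected for compound 4, estimated as a number 21.1 percentage points lower from compound 3 to compound 4 (beyond the scatter). Compound 4 is therefore expected to give about 35%, with a likely range from 15% to 58%.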

Compound 4, a percentage reported as inhibition, at one concentration (the size of the read-out at that concentration, not a potency): 44.4%
Beside the measured number, compound 4's estimate is 9.4 percentage points below it; low and high end bracket the measured number.
By their numbers in this assay, from the lowest: compound 2; then compound 4; then compounds 3 and 1 (each within the scatter of the next).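

In this assay, removing the tether altogether gives a number 11.7 percentage points lower from compound 3 to compound 4 (beyond the scatter) and a number 12.2 percentage points lower from compound 1 to compound 4 (beyond the scatter) but also a number 11.5 percentage points higher from compound 2 to compound 4 (beyond the scatter) for this position on the aromatic ring. The numbers therefore do not simply fall as the tether shortens: compound 4, with the isothiocyanate attached directly to the aromatic carbon, goes against that trend by standing above compound 2, which keeps a tether. Nothing presented here explains this order.

The compounds shown leave open whether the low number of compound 2 follows from the length of its chain or from the way that chain is attached to the ring, which a longer chain on the same attachment could separate. They also leave open how much of the effect depends on the isothiocyanate itself, which an amine in its place could address.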